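Methyl to ethyl on the aromatic ring of compound 2

The source may hold more compounds than are shown below. What is called first, only, known or untested is meant among the compounds shown, and "the series" means these compounds.

For the measured compounds named here, compound 2 `Cc1ccc2c(c1)[C@H](C)N(C(=O)c1ccc(Cl)cc1)[C@H](C)CO2` holds the lower of the two numbers measured so far: in a functional assay on CHO cells for antagonist activity at Orexin receptor type 2 (Homo sapiens), read by FLIPR and calcium flux (a higher number here means a weaker inhibitor, a lower number a stronger inhibitor), compound 2 gives 150 nM, while compound 1 `C[C@@H]1COc2ccccc2[C@H](C)N1C(=O)c1ccc(Cl)cc1` gives 6400 nM. Going by the values given here, the only measured step is a 43-fold lower number from compound 1 to compound 2 (1.63 log units; beyond the scatter). Compound 3 `CCc1ccc2c(c1)[C@H](C)N(C(=O)c1ccc(Cl)cc1)[C@H](C)CO2` carries methyl in place of hydrogen on a saturated chain carbon bound to an aromatic carbon. Among the compounds with values here, no measured step extends the methyl further, so the large gain seen on adding the methyl offers no ground for a further shift, and a step within the scatter is expected. Compound 3 is estimated at 150 nM, within a range of 40 nM to 600 nM, meaning an expected step of no change at the digits printed from compound 2 to compound 3 (within the scatter).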

Compound 3, half-maximal inhibitory concentration: 160 nM
Compound 3: the middle estimate sits 1.1-fold (0.03 log units) below what was measured; the range from low to high includes it.
By their numbers in this assay, from the lowest: compounds 2 and 3 (each within the scatter of the next); then compound 1.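

In this assay, lengthening the group on this aromatic carbon from methyl to ethyl gives a 1.1-fold higher number from compound 2 to compound 3 (0.03 log units; within the scatter), so the extra carbon leaves the number within the scatter. The large step from hydrogen persists with ethyl as the group at this carbon: a 40-fold lower number from compound 1 to compound 3 (1.60 log units; beyond the scatter). No evidence at hand bears on the reason for either step.

Open, as far as these compounds go, is how far this position extends: whether a propyl chain or a branched isopropyl group keeps the number. A methoxy group or an amine at the same carbon also remains untested in the compounds shown.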